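Adding a methyl to the most active alkene

The source may report more compounds than this note shows. Statements on the series, on what has been measured and on what is new or still open speak of the compounds shown alone.

Measured so far in a functional assay on HL-60 cells (Homo sapiens) for inhibition; a higher number here means a weaker inhibitor, a lower number a stronger inhibitor:
Compound 1 (`COc1cc(/C=C\c2cn(C)c3ccccc23)cc(OC)c1OC`) gives 3090 nM
Compound 2 (`COc1cc(/C=C/c2ccc3[nH]ccc3c2)cc(OC)c1OC`) gives 380 nM
Compound 3 (`COc1cc(/C=C\c2ccc3[nH]ccc3c2)cc(OC)c1OC`) gives 35 nM

Compound 3 holds the lowest number of the three, making it the strongest inhibitor so far. Compound 4 (`COc1cc(/C=C\c2ccc3c(ccn3C)c2)cc(OC)c1OC`) is compound 3 with methyl in place of hydrogen on an aromatic nitrogen. For the measured compounds named here, no measured step isolates this change. Going by the values given here, the only measured step, an 11-fold lower number from compound 2 to compound 3 (1.04 log units; beyond the scatter), is large, and it rests on (the fact that compounds 2 and 3 differ only in the configuration as drawn), so it concerns the double bond and not the nitrogen. Compound 1 gives 3090 nM and also carries a methyl on an aromatic nitrogen. It stands far higher than compound 3 but differs from it elsewhere too, so it offers only a weak hint towards a higher number. A small rise in this assay, not beyond the scatter, is therefore expected, with an estimated step of a 1.4-fold higher number from compound 3 to compound 4 (0.15 log units; within the scatter). Compound 4 is expected at 50 nM, with an estimated range of 12 nM to 220 nM.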

Compound 4, half-maximal inhibitory concentration: 330 nM
Estimate against measurement, compound 4: 6.6-fold (0.82 log units) below; the measured number lies above the stated range.
By their numbers in this assay, from the lowest: compound 3; then compounds 4 and 2 (each within the scatter of the next); then compound 1.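

In this assay, for the compounds shown here, methyl in place of hydrogen on the aromatic nitrogen brings a 9.4-fold higher number from compound 3 to compound 4 (0.97 log units; beyond the scatter) and so gives the first direct reading of this position. The change adds only one carbon, yet compound 4 is a clearly weaker inhibitor than compound 3, so this hydrogen cannot be replaced by methyl without a loss of inhibition while the rest of the molecule stays the same. The one fact on record concerns the double bond and does not bear on what happens at this nitrogen.

From the compounds shown here alone, it remains open whether the loss is particular to methyl or extends to other groups on that nitrogen, such as an ethyl, an acetyl or a longer chain. Also open, going by these compounds, is how the same methyl would act on the E alkene of compound 2.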